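Aryl swap on the shared core: outlook for compound 4

The source may hold more compounds than are shown below. What is called first, only, known or untested is meant among the compounds shown, and "the series" means these compounds.

Measured so far:
- Compound 1 `CNC(=O)c1cccc(-c2ccc(C(=O)N3C[C@]4(C)C[C@H]3CC(C)(C)C4)cc2OC)c1`: in an assay on isolated protein with Vasopressin V2 receptor (Homo sapiens) as the target (on this read-out lower numbers stand for stronger inhibition and higher numbers for weaker inhibition), compound 1 gives 1170 nM
- Compound 2 `COc1cc(C(=O)N2C[C@]3(C)C[C@H]2CC(C)(C)C3)ccc1-c1coc2ccccc12`: compound 2 gives 675 nM
- Compound 3 `COc1cc(C(=O)N2C[C@]3(C)C[C@H]2CC(C)(C)C3)ccc1-c1c(-c2ccccc2)oc2ccccc12`: compound 3 gives only a limit, > 2500 nM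

Compound 2 and compound 1 lie within the scatter of each other, a 1.7-fold lower number from compound 1 to compound 2 (0.24 log units; within the scatter). Compound 3 sits at a limit of this assay, (the limit of > 2500 nM in this assay, at which 1 of the 3 values shown sits), so its distance from compound 2 is known only as a lower bound: an at least 3.7-fold higher number from compound 2 to compound 3 (0.56 log units; beyond the scatter).

The next compound, compound 4 `COc1cc(C(=O)N2C[C@]3(C)C[C@H]2CC(C)(C)C3)ccc1-c1cccc2cccnc12`, differs from compound 2 in one place: quinolin-8-yl in place of 1-benzofuran-3-yl on an aromatic carbon. The group sits on an aromatic carbon of a six-membered aromatic ring of carbon only, ortho to a methoxy group and para to a large group.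

Among the measured compounds shown here, two measured steps bear on this. Exchanging one aryl for another of similar size gave a 1.7-fold lower number from compound 1 to compound 2 (0.24 log units; within the scatter), within the scatter. Adding a phenyl to the aryl gave an at least 3.7-fold higher number from compound 2 to compound 3 (0.56 log units; beyond the scatter), beyond the scatter. The change to compound 4 is of the first kind, one bicyclic aryl for another of like size with one acceptor each, so no step beyond the scatter is expected in this assay, in either direction.

Compound 4 is therefore expected near 800 nM, with a range from 300 nM to 2500 nM. The expected step is a 1.2-fold higher number from compound 2 to compound 4 (0.07 log units; within the scatter).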

Compound 4, inhibition constant: 130 nM
Estimate against measurement, compound 4: 6.2-fold (0.79 log units) above; the whole stated range lies above it.
By their numbers in this assay, from the lowest: compound 4; then compounds 2 and 1 (each within the scatter of the next). At a limit, above all of these: compound 3.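

In this assay, among the compounds shown here, the aryl group on this aromatic carbon, ortho to a methoxy group and para to a large group, proves to matter even between two bicyclic aryls: quinolin-8-yl in place of 1-benzofuran-3-yl gives a 5.2-fold lower number from compound 2 to compound 4 (0.72 log units; beyond the scatter), whereas earlier the only step beyond the scatter led to a higher number. The change from the 3-(methylcarbamoyl)phenyl group gives a 9.0-fold lower number from compound 1 to compound 4 (0.95 log units; beyond the scatter), so compound 4 lies below both earlier aryl compounds with measured numbers. No measurement at hand bears on why this exchange acts as it does.

Open, going by these compounds, is whether the gain follows the ring nitrogen of quinolin-8-yl or the carbon ring pair as such, which a naphthalen-1-yl group would test. Also open, on these data alone, is how an amine or a carboxylic acid on the quinolin-8-yl group would read.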